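This account rests on a few compounds, and the source may have more. Where it says the series, first, only, none or still open, it means among the compounds named here.

Measured so far in an in vitro ADME assay on microsomes from liver (Rattus norvegicus) for metabolic stability (on this read-out higher numbers stand for fast clearance and lower numbers for slow clearance), each value a limit and not a number:
- compound 1 (`Cc1ccc(Cn2c(=O)[nH]c3c(N)nc(C(F)(F)F)cc32)cn1`) gives < 8.5 mL.min-1.g-1 as a limit
- compound 2 (`Cc1cc(Cn2c(=O)[nH]c3c(N)nc(C(F)(F)F)cc32)no1`) gives < 9 mL.min-1.g-1 as a limit
- compound 3 (`Nc1nc(C(F)(F)F)cc2c1[nH]c(=O)n2Cc1ccc(C(F)(F)F)nc1`) gives < 8.5 mL.min-1.g-1 as a limit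

Compound 3 therefore has only a limit (< 8.5 mL.min-1.g-1) and no number. Compound 4 (`COc1ccc(Cn2c(=O)[nH]c3c(N)nc(C(F)(F)F)cc32)cn1`) carries methoxy in place of trifluoromethyl on an aromatic carbon, next to the ring nitrogen (methoxy in place of trifluoromethyl on an aromatic carbon). The closest measured change sits on that same carbon (a step that the two limits leave unreadable from compound 1 to compound 3). The other swaps the whole ring (a step that the two limits leave unreadable from compound 1 to compound 2). Neither offers a size to carry over. The estimated change (a step that the limit leaves unreadable from compound 3 to compound 4) is therefore expected to stay within the usual scatter of this assay, with no direction favoured. For compound 4 the expected value is 8 mL.min-1.g-1 with an estimated range from 4 mL.min-1.g-1 to 16 mL.min-1.g-1 and a fair chance of another limit.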

Compound 4, intrinsic clearance in microsomes: < 9 mL.min-1.g-1
Compound 4 ended at the assay's limit; the forecaster's own chance of this, stated with the estimate: 65%; the middle value lies beyond the limit too.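

Compound 4 gives only a limit, as do compounds 1, 2 and 3, so no step among these four compounds can be read: the limit of < 9 mL.min-1.g-1 in this assay, at which 2 of the 4 values shown sit.

On these data alone, how fast each is truly cleared in this assay, and whether methoxy, methyl and trifluoromethyl differ at all, stays open.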